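The compounds below may be only part of what the source reports. "The series", "measured", "known", "first", "only" and "open" are said of these compounds alone.

In an ADME assay on Vero 76 cells (Chlorocebus sabaeus) for cytotoxicity, read by crystal violet staining, with a stated time of 96 h (on this read-out lower numbers stand for higher toxicity in this test and higher numbers for lower toxicity in this test), so far:
- compound 1 (`CC[C@H]1CC[C@H](c2ccc(NC(=S)Nc3cccc(C(F)(F)F)c3)cc2)CC1`) gives 10000 nM as its half-maximal cytotoxic concentration
- compound 2 (`CCCC[C@H]1CC[C@H](c2ccc(NC(=S)Nc3cccc(C(F)(F)F)c3)cc2)CC1`) gives 17000 nM on the same read-out
- compound 3 (`N#Cc1ccc(NC(=S)Nc2cccc(C(F)(F)F)c2)cc1`) is not yet measured

For the measured compounds named here, compound 2 (17000 nM) stands within the scatter of compound 1, its only measured neighbour. The move to compound 3 is cyano in place of 4-butylcyclohexyl on an aromatic carbon in short: cyano in place of 4-butylcyclohexyl on an aromatic carbon. Going by the values given here, only one measured step bears on this (a 1.7-fold higher number from compound 1 to compound 2 (0.23 log units; within the scatter)), and it concerns a saturated chain, not the loss of the whole 4-butylcyclohexyl, so it is a weak guide. From the compounds shown here alone, no step beyond the scatter is therefore expected in this assay for now, and the direction stays open. The expected step (a 1.2-fold higher number from compound 2 to compound 3 (0.07 log units; within the scatter)) is accordingly small, with low confidence. For compound 3 the estimated value is 20000 nM (expected range 7000 nM to 60000 nM).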

Compound 3, half-maximal cytotoxic concentration: 10000 nM
The estimate for compound 3 lay 2.0-fold (0.30 log units) above the measured number; the range from low to high includes it.
By their numbers in this assay, from the lowest: compounds 1, 3 and 2 (each within the scatter of the next).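

In this assay, cyano in place of 4-butylcyclohexyl on an aromatic carbon gives a 1.7-fold lower number from compound 2 to compound 3 (0.23 log units; within the scatter), and cyano in place of 4-ethylcyclohexyl on the same carbon gives no change at the digits printed from compound 1 to compound 3 (within the scatter). This position therefore tolerates loss of the whole group, saturated ring included, with no step beyond the scatter in this read-out, whereas the earlier step reached only the saturated chain. Nothing available accounts for this lack of separation among the three compounds.

From the compounds shown here alone, whether an amine, a carboxylic acid or a longer chain on this aromatic carbon would give a step beyond the scatter stays open. Also open, going by these compounds, is whether the numbers stay this close when the trifluoromethyl group shared by all three compounds gives way to another group.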